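The source may hold more compounds than are shown below. What is called first, only, known or untested is meant among the compounds shown, and "the series" means these compounds.

Compound 1, `CCC(CC)(c1ccc(OCCCCCO)c(C)c1)c1ccc(OCC(O)C(C)(C)C)c(OCC(O)C(C)(C)C)c1`, and compound 2, `CCC(CC)(c1ccc(OCCCCCCO)c(C)c1)c1ccc(OCC(O)C(C)(C)C)c(OCC(O)C(C)(C)C)c1`, share one core and differ only at the end of the chain that hangs from an aromatic oxygen. In an assay on cells for binding affinity to vitamin D3 receptor (Homo sapiens), read by fluorescence, tested at 1 uM (a higher number here means more inhibition at the concentration tested (going by the name of the read-out), a lower number less inhibition), compound 1 gives 67%, and compound 2 gives 52%. Going by the values given here, the step of a number 15 percentage points lower from compound 1 to compound 2 (beyond the scatter) is the only measured step in this pair, and it leaves compound 2 standing at the lower of the two numbers, with compound 1 as its nearest neighbour.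

Compound 3, `CCC(CC)(c1ccc(OCCCCCC(=O)O)c(C)c1)c1ccc(OCC(O)C(C)(C)C)c(OCC(O)C(C)(C)C)c1`, has not yet been measured. Relative to compound 2 it carries carboxy in place of hydroxymethyl on a saturated chain carbon, five bonds along the chain from an oxygen on an aromatic ring. Among the compounds with values here, no measured step mirrors this change: the single step from compound 1 to compound 2 concerns chain length, not the identity of the terminal group, so it gives only indirect guidance. The chain length of compound 3 matches that of compound 2, so the author expects no step beyond the scatter, with an estimated change of a number 2 percentage points lower from compound 2 to compound 3 (within the scatter) in this assay. For compound 3 the estimate in this assay is 50%, within a range from 30% to 70%.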

Compound 3, a percentage reported as inhibition, at one concentration (the size of the read-out at that concentration, not a potency): "not active" (no number reported)
Compound 3: no number reported; there is nothing to compare the estimate with.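

In this assay, going by these compounds alone, compound 3 is recorded as "not active" with no number, so no step from compound 2 to compound 3 can be read. The compounds shown leave open how large a change carboxy in place of hydroxymethyl makes at this place on the chain. No supporting data bear on this result.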